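The source may hold more compounds than are shown below. What is called first, only, known or untested is meant among the compounds shown, and "the series" means these compounds.

Compound 1 `Cc1ccccc1NC(=O)Nc1cccc(CNc2ncnc3ccccc23)c1` carries a 2-methylphenyl on an amide-type nitrogen of the shared core. In a functional assay on MGC-803 cells (Homo sapiens) for antiproliferative activity, read by MTT assay (a higher number here means a weaker inhibitor, a lower number a stronger inhibitor), compound 1 gives only a limit of the assay, > 50000 nM, and no number. Two measured compounds replace that group. Compound 2 `Cc1ccc(NC(=O)Nc2cccc(CNc3ncnc4ccccc34)c2)cc1` gives 31200 nM in this assay, a change of an at least 1.6-fold lower number from compound 1 to compound 2 (0.20 log units; that floor lies within the scatter). Compound 3 `CC(C)(C)c1ccc(NC(=O)Nc2cccc(CNc3ncnc4ccccc34)c2)cc1` gives 7470 nM in this assay, a change of an at least 6.6-fold lower number from compound 1 to compound 3 (0.82 log units; beyond the scatter), and the step from compound 2 to compound 3 is a 4.2-fold lower number from compound 2 to compound 3 (0.62 log units; beyond the scatter). The unmeasured compound 4 `O=C(Nc1ccc(F)cc1)Nc1cccc(CNc2ncnc3ccccc23)c1` differs from compound 1 by 4-fluorophenyl in place of 2-methylphenyl on an amide-type nitrogen. Both measured replacements of 2-methylphenyl moved the number downward, the 4-methylphenyl of compound 2 only within the scatter, the 4-(tert-butyl)phenyl of compound 3 by a modest step. Compound 4 bears neither of those groups, so it is expected to land near compound 2 rather than compound 3. Compound 4 is therefore expected to give about 35000 nM in this assay, with a range from 12000 nM to 60000 nM. That estimate implies a step of an at least 1.4-fold lower number from compound 1 to compound 4 (0.15 log units; that floor lies within the scatter), though the assay may again report only a limit.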

Compound 4, half-maximal inhibitory concentration: 44300 nM
Compound 4: middle estimate off by 1.3-fold (0.10 log units), on the low side, within the range that was stated.
By their numbers in this assay, from the lowest: compound 3; then compounds 2 and 4 (each within the scatter of the next). At a limit, above all of these: compound 1.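

In this assay, fluoro in place of methyl on an aromatic carbon gives a 1.4-fold higher number from compound 2 to compound 4 (0.15 log units; within the scatter), while fluoro in place of tert-butyl gives a 5.9-fold higher number from compound 3 to compound 4 (0.77 log units; beyond the scatter). Among these three compounds, then, only the 4-(tert-butyl)phenyl of compound 3 stands apart, and the methyl of compound 2 and the fluoro of compound 4 cannot be told apart. Compound 1 remains a limit of the assay and not a number, so 4-fluorophenyl in place of 2-methylphenyl gives only a floor, an at least 1.1-fold lower number from compound 1 to compound 4 (0.05 log units; that floor lies within the scatter): the limit of > 50000 nM in this assay, at which 1 of the 4 values shown sits.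

On these data alone, what a methoxy, a trifluoromethyl or a dimethylamino group would do in place of the tert-butyl of compound 3 stays open. Also open, as far as these compounds go, is whether 2-methylphenyl truly differs from 4-fluorophenyl at all, which that floor does not settle.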